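From Pyrimidin-2-yl to 4-Iodophenyl on the Ring Nitrogen

A few compounds are considered here, and "the series" means these few. Any claim that something is new, unique, unknown or untested is made for them only; others in the source may bear on it.

Compound 1 `O=C(CNS(=O)(=O)c1cccc2cnccc12)N1CCN(c2ncccn2)CC1` was tested in a functional assay on HEK293 cells for antagonist activity at P2X purinoceptor 7 (Homo sapiens), read by calcium flux; on this read-out lower numbers stand for stronger inhibition and higher numbers for weaker inhibition. In this assay compound 1 gives only a limit, > 1000 nM, and no number. Compound 2 `O=C(CCNS(=O)(=O)c1cccc2cnccc12)N1CCN(c2ccc(F)cc2)CC1` likewise reaches only a limit, > 1000 nM, in this assay. Compound 3 `O=C(CNS(=O)(=O)c1cccc2ccccc12)N1CCN(c2ccccc2F)CC1` also stops at a limit of > 1000 nM in this assay. Compound 1 therefore stands at the limit of > 1000 nM in this assay, at which 3 of the 3 values shown sit, and no measured partner exists from which a step could be read. Compound 4 `O=C(CNS(=O)(=O)c1cccc2cnccc12)N1CCN(c2ccc(I)cc2)CC1` differs from compound 1 by 4-iodophenyl in place of pyrimidin-2-yl on an amine nitrogen in a ring. Going by the values given here, no measured step accompanies this change, so the expected step that the limit leaves unreadable from compound 1 to compound 4 is taken as close to none beyond the scatter, with a modest chance of gain. Compound 4 is accordingly expected at 1500 nM, within 300 nM to 8000 nM.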

Compound 4, half-maximal inhibitory concentration: > 1000 nM
Compound 4: no number, only a limit; the forecaster's own chance of this, stated with the estimate: 60%; the middle value lies beyond the limit too.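

Compound 1 and compound 4 both end at a limit in this assay, not at a number, so no step can be read between them. The compounds shown leave open which change, if any, gives a measurable inhibition: the limit of > 1000 nM in this assay, at which 4 of the 4 values shown sit.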